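The compounds below may be only part of what the source reports. "The series", "measured", "known", "first", "only" and "open" are said of these compounds alone.

Compound 1 `CC(=O)Nc1nc2ccc(-c3cn([C@@H]4CN[C@H](C(=O)Nc5ccc(Cl)cc5Cl)C4)nn3)nc2s1` and compound 2 `Nc1nc2ccc(-c3cn([C@@H]4CN[C@H](C(=O)Nc5ccc(Br)cc5)C4)nn3)nc2s1` share one core and differ in the aromatic amine substituent and the anilide. In a functional assay on K562/Adr cells (Homo sapiens) for inhibition, read by MTT assay, with a stated time of 48 h, tested at 30 uM (a higher number here means more inhibition at the concentration tested (going by the name of the read-out), a lower number less inhibition), compound 1 gives 36.1%; in this assay compound 2 gives 35.9%, and the two values lie within the scatter of each other. Compound 3 `CC(=O)Nc1nc2ccc(-c3cn([C@@H]4CN[C@H](C(=O)Nc5ccc(Br)cc5)C4)nn3)nc2s1` is the next member. Compound 3 differs from compound 2 in one place: acetyl in place of hydrogen on a nitrogen on an aromatic ring. Among the compounds with values here, no step between measured compounds covers this change; compound 1 already carries the acetamido group, and its value 36.1% sits where compound 2 does. The step of a number 0.1 percentage points higher from compound 2 to compound 3 (within the scatter) is therefore expected to be none beyond the scatter. Compound 3 is estimated at 36%, between 25% and 47%.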

Compound 3, a percentage reported as inhibition, at one concentration (the size of the read-out at that concentration, not a potency): 32%
Compound 3: middle estimate off by 4 percentage points, on the high side; the range from low to high includes it.
By their numbers in this assay, from the lowest: compounds 3, 2 and 1 (each within the scatter of the next).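

In this assay, within the data shown here, acetyl in place of hydrogen on a nitrogen on an aromatic ring gives a number 3.9 percentage points lower from compound 2 to compound 3 (within the scatter) and so provides the first direct reading of amino to acetamido, with no change beyond the scatter. On the amide-type nitrogen, 4-bromophenyl in place of 2,4-dichlorophenyl gives a number 4.1 percentage points lower from compound 1 to compound 3 (within the scatter) and likewise stays inside the scatter. Nothing available bears on the reason for either step. The compounds shown leave open whether a longer acyl chain such as butanoyl on that aromatic amine would read differently. They also leave open how an anilide ring carrying a carboxylic acid would read.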